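The source may report more compounds than this note shows. Statements on the series, on what has been measured and on what is new or still open speak of the compounds shown alone.

In a functional assay on HepG2 cells (Homo sapiens) for inhibition, read by MTT assay, with a stated time of 120 h (on this read-out lower numbers stand for stronger inhibition and higher numbers for weaker inhibition), compound 1 `O=C(/C=C/c1ccc(NC(=O)Nc2ccc(Cl)c(C(F)(F)F)c2)cc1)NC1CCC1` gives 7510 nM. Compound 2 `O=C(CCc1ccc(NC(=O)Nc2ccc(Cl)c(C(F)(F)F)c2)cc1)NC1CCC1` gives > 50000 nM, which is a limit of the assay. From the compounds shown here alone, compound 3 `CNC(=O)/C=C(\C)c1ccc(NC(=O)Nc2ccc(Cl)c(C(F)(F)F)c2)cc1` gives > 50000 nM, also a limit, so its true place is unknown. Compound 4 `CNC(=O)C#Cc1ccc(NC(=O)Nc2ccc(Cl)c(C(F)(F)F)c2)cc1` carries 2-(methylcarbamoyl)ethynyl in place of 1-methyl-2-(methylcarbamoyl)ethenyl on an aromatic carbon. Going by the values given here, two measured steps bear on this change: an at least 6.6-fold higher number from compound 1 to compound 2 (0.82 log units; beyond the scatter) and an at least 6.6-fold higher number from compound 1 to compound 3 (0.82 log units; beyond the scatter). Each ends at a limit, so neither gives an exact size. Compound 4 lacks the 1-methyl group, as does compound 1 at 7510 nM, so a modest move towards a lower number is expected. The expected change is an at least 1.6-fold lower number from compound 3 to compound 4 (0.22 log units; that floor lies within the scatter), though it may not be readable if compound 4 also stays at the limit. The estimated value for compound 4 is 30000 nM, within an expected range of 10000 nM to 50000 nM.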

Compound 4, half-maximal inhibitory concentration: 23300 nM
The estimate for compound 4 lay 1.3-fold (0.11 log units) above the measured number, within the range that was stated.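

Replacing 1-methyl-2-(methylcarbamoyl)ethenyl with 2-(methylcarbamoyl)ethynyl gives an at least 2.1-fold lower number from compound 3 to compound 4 (0.33 log units; beyond the scatter), so this position can hold a chain with a triple bond and a small methyl amide and still give a readable number. Replacing 2-(cyclobutylcarbamoyl)ethyl gives an at least 2.1-fold lower number from compound 2 to compound 4 (0.33 log units; beyond the scatter), and both sizes are only floors because each starts from a limit: the limit of > 50000 nM in this assay, at which 2 of the 4 values shown sit. Replacing 2-(cyclobutylcarbamoyl)ethenyl gives a 3.1-fold higher number from compound 1 to compound 4 (0.49 log units; beyond the scatter), so inhibition weakens but is not lost.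

From the compounds shown here alone, that last change alters both the linking chain and the amide group, so the share of each stays open. Going by these compounds, how 2-(cyclobutylcarbamoyl)ethynyl, or a carboxylic acid in place of the amide, would read also remains open.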